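The compounds below may be only part of what the source reports. "The series", "measured", "known", "first", "only" and "open" are said of these compounds alone.

Working notes on the series. Compound 1 `C[C@H](Nc1nc(N)nc(N)c1C#N)c1cc(=O)n2cc(F)ccc2c1-c1ccc(F)cc1` has in an ADME assay on microsomes from liver (Mus musculus), read by LC-MS, using NADPH, with a stated time of 30 min, tested at 1 uM (a lower number here means that less of the compound is left, a higher number that more of the compound is left), only the entry "not determined" (no result reported) and so no result. Going by the values given here, compound 2 `C[C@H](Nc1ncnc(N)c1C#N)c1c(C2CC2)c(=O)n2cc(F)ccc2c1-c1ccc(F)cc1` is the only member of the set with a number: in this assay compound 2 gives 52%, which leaves it as the sole reference point and allows no ordering against another compound. Compound 3 `C[C@H](Nc1nc(N)nc(N)c1C#N)c1c(C2CC2)c(=O)n2cc(F)ccc2c1-c1ccc(F)cc1` is the next member to be measured. Compound 3 differs from compound 2 in one place: amino in place of hydrogen on an aromatic carbon, so that the (6-amino-5-cyanopyrimidin-4-yl)amino unit of compound 2 becomes the (2,6-diamino-5-cyanopyrimidin-4-yl)amino unit of compound 3. Among the compounds with values here, no pair of measured compounds in the set carries this change, so the size of the step is not backed by any measured comparison. The step expected from compound 2 to compound 3 is small, a number 6 percentage points higher from compound 2 to compound 3 (within the scatter), within or barely beyond the usual scatter. For compound 3 the estimate in this assay is 58%, with a range from 35% to 80%.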

Compound 3, percent of the compound remaining: 75%
Compound 3: the middle estimate sits 17 percentage points below what was measured, and the stated range covers the measured number.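

Amino in place of hydrogen on the aromatic carbon between two ring nitrogen atoms comes with a number 23 percentage points higher from compound 2 to compound 3 (beyond the scatter) in this assay and gives the set its first measured step. It shows that this position is not indifferent in this read-out, as more of the compound is left with the (2,6-diamino-5-cyanopyrimidin-4-yl)amino unit than with the (6-amino-5-cyanopyrimidin-4-yl)amino unit. Nothing at hand bears on the reason for this step, which rests on a single pair.

As far as these compounds go, whether a small group other than amino at this position, such as methyl or methoxy, would go the same way stays open. From the compounds shown here alone, compound 1 carries no number, so steps to it cannot be read, and it is unknown whether the step holds on any other version of the core.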